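Cytotoxicity on Fibroblasts: a Benzyl Swap on a Shared Core

This account rests on a few compounds, and the source may have more. Where it says the series, first, only, none or still open, it means among the compounds named here.

Compound 1 `COC(=O)c1ccc(NCc2cncn2Cc2cccc(Cl)c2)cc1-c1ccccc1`: > 10000 nM
Compound 2 `CC(=O)c1ccc(NCc2cncn2Cc2ccc(-c3ccccc3)cc2)cc1-c1ccccc1`: > 10000 nM

In a toxicity assay on NIH3T3 cells (Mus musculus) for cytotoxicity, read by resazurin assay (a lower number here means that less compound is needed, a higher number that more compound is needed for the effect), compound 1 gives > 10000 nM, which is a limit of the assay and not a number. Compound 2 gives > 10000 nM, again only a limit. Compound 1 thus stands where every value here stands: the limit of > 10000 nM in this assay, at which 2 of the 2 values shown sit. Compound 3 `COC(=O)c1ccc(NCc2cncn2Cc2ccccc2[N+](=O)[O-])cc1-c1ccccc1` differs from compound 1 by 2-nitrophenyl in place of 3-chlorophenyl on a saturated chain carbon bound to an aromatic nitrogen. Among the compounds with values here, with no step between measured compounds available, the step that the limit leaves unreadable from compound 1 to compound 3 is expected to show no change beyond the scatter. Compound 3 is therefore estimated at 20000 nM, with a range from 8000 nM to 60000 nM.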

Compound 3, half-maximal effective concentration: 10000 nM
Compound 3: middle estimate off by 2.0-fold (0.30 log units), on the high side; measured number inside the range.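

In this assay, within the data shown here, compound 3 gives 10000 nM, the first actual number. On a saturated chain carbon bound to an aromatic nitrogen, 2-nitrophenyl in place of 3-chlorophenyl gives a number no higher from compound 1 to compound 3 (the limit leaves the size open), so this position can carry a change that brings the read-out off the limit, though by how much cannot be read. The other values remain limits: the limit of > 10000 nM in this assay, at which 2 of the 3 values shown sit.

Still open, from the compounds shown here alone, is whether a benzyl group carrying an amine or a carboxylic acid at this position would give a lower number. Going by these compounds, whether the same swap would read alike with the ketone of compound 2 in place of the methyl ester is also open.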